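This account rests on a few compounds, and the source may have more. Where it says the series, first, only, none or still open, it means among the compounds named here.

Three compounds have been measured in an assay on isolated protein for inhibition of 3',5'-cyclic-AMP phosphodiesterase 4A (Cavia porcellus), read by cAMP accumulation, tested at 10 uM; on this read-out lower numbers stand for a weaker effect and higher numbers for a stronger effect at the one concentration tested:

Compound 1, `CC(=O)c1cc(C(=O)c2ccccc2)c(=O)[nH]c1C`, gives 2% in this assay.
Compound 2, `O=C(c1ccccc1)c1cc(C(=O)c2ccccc2)c(=O)[nH]c1-c1ccccc1`, gives 1.76% in this assay.
Compound 3, `CC(=O)c1cc(S(=O)(=O)c2ccccc2)c(=O)[nH]c1C`, gives 1.03% in this assay.

All three numbers sit close to the bottom of the scale, and the gaps between them are smaller than the scatter of repeated measurements, so none of the three can be told apart from the others. Compound 1 stands in this cluster: its number differs from that of compound 2 and from that of compound 3 by less than the usual scatter, and nothing in these three results marks it out.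

Compound 4, `CC(=O)c1cc(C(=O)C(C)(C)C)c(=O)[nH]c1C`, has not yet been measured. It is reached from compound 1 by a single change: tert-butyl in place of phenyl on a carbonyl carbon. The shared core of compound 1 and compound 4 is otherwise untouched.

Among the measured compounds shown here, no pair of measured compounds differs in just one place, so there is no measured step to lean on. What the three numbers do show is that neither a phenyl nor a methyl at the corresponding carbonyl, nor a change elsewhere on the core, has lifted any compound out of the low cluster. The step of no change at the digits printed from compound 1 to compound 4 (within the scatter) is therefore expected to stay within the scatter, with no direction to it. Compound 4 is estimated to give 2% in this assay, with a likely range from -6% to 10%.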

Compound 4, a percentage reported as inhibition, at one concentration (the size of the read-out at that concentration, not a potency): 1.15%
Estimate against measurement, compound 4: 0.9 percentage points above; low and high end bracket the measured number.
By their numbers in this assay, from the lowest: compounds 3, 4, 2 and 1 (each within the scatter of the next).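

Among the compounds shown here, this is the first step where only one place changes: in this assay, putting tert-butyl in place of phenyl on a carbonyl carbon gives a number 0.9 percentage points lower from compound 1 to compound 4 (within the scatter) for this swap. At this position, then, a six-membered aromatic ring can give way to a group with no ring and fewer heavy atoms, and the read-out stays in the same low cluster. Phenyl and tert-butyl cannot be told apart here, so this single step gives no sign that either group is preferred at this place, although one step between two groups made only of carbon and hydrogen is a narrow test.

On these data alone, neither group on this carbonyl carbon has any hydrogen-bond donors or acceptors, so it remains open whether a longer chain ending in an amine or a carboxylic acid would lift the number clear of the scatter. No measurement shown here explains why phenyl and tert-butyl read alike, or why all four compounds sit so close to the bottom of the scale.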